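A few compounds are considered here, and "the series" means these few. Any claim that something is new, unique, unknown or untested is made for them only; others in the source may bear on it.

Measured so far:
compound 1, `Cc1nc(Nc2ccc3sc(C(=O)Nc4c(C)cccc4Cl)cc3c2)cc(N2CCCCC2)n1`, with 8.78%
compound 2, `Cc1nc(Nc2ccc3sc(C(=O)Nc4c(C)cccc4Cl)cc3c2)cc(N2CCC(C)CC2)n1`, with 20.5%

Going by the values given here, in a functional assay on K562 cells (Homo sapiens) for inhibition, read by MTT assay and WST assay, with a stated time of 72 h, tested at 10 uM (a higher number here means more inhibition of growth at the concentration tested, a lower number less inhibition of growth), compound 2 gives 20.5%, the higher of the two numbers so far; the only other measured compound, compound 1, gives 8.78%. Among the compounds with values here, the single measured step, a number 11.7 percentage points higher from compound 1 to compound 2 (beyond the scatter), concerns a methyl on the saturated ring and nothing else. Compound 3, `Cc1nc(Nc2ccc3sc(C(=O)Nc4c(C)cccc4Cl)cc3c2)cc(N2CCN(C)CC2)n1`, has not yet been measured. It differs from compound 2 by 4-methylpiperazin-1-yl in place of 4-methylpiperidin-1-yl on an aromatic carbon. Within the data shown here, no measured step swaps a ring carbon for a ring nitrogen in this way, so the step from compound 1 to compound 2 bears only loosely on it; the entering group keeps the same ring size and the same methyl, and the two measured values are themselves modest. Compound 3 is expected to stay close to compound 2, with a number 4.5 percentage points lower from compound 2 to compound 3 (within the scatter), a step not beyond the scatter. The estimate for compound 3 is 16%, ranging from 0% to 35%.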

Compound 3, percent growth inhibition at one concentration: 32.4%
The estimate for compound 3 lay 16.4 percentage points below the measured number; low and high end bracket the measured number.
By their numbers in this assay, from the lowest: compound 1; then compound 2; then compound 3.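

In this assay, exchanging the 4-methylpiperidin-1-yl group for 4-methylpiperazin-1-yl gives a number 11.9 percentage points higher from compound 2 to compound 3 (beyond the scatter), so this position responds to a ring carbon becoming a ring nitrogen, not only to the added methyl seen earlier. Taken together with that methyl, the change from piperidin-1-yl to 4-methylpiperazin-1-yl gives a number 23.6 percentage points higher from compound 1 to compound 3 (beyond the scatter), the largest step among these compounds, though still a modest one. No available measurement explains why the second ring nitrogen goes with more growth inhibition.

On these data alone, it remains open whether the methyl is needed on the new nitrogen, which a plain piperazin-1-yl group would test, and whether morpholin-4-yl, with an oxygen in that ring place, would behave alike. As far as these compounds go, it is also open whether this order would hold at other concentrations.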